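The compounds below may be only part of what the source reports. "The series", "measured", "known", "first", "only" and "open" are said of these compounds alone.

Of the compounds shown here, three sharing one core have so far been measured in a functional assay on NCI-H522 cells (Homo sapiens) for inhibition, read by sulforhodamine B assay, with a stated time of 48 h; on this read-out lower numbers stand for higher toxicity in this test and higher numbers for lower toxicity in this test. Compound 1 `COc1cc(C)cc(-c2nn(CC#N)cc2-c2ccc(-c3cccc(C(C)=O)c3)nc2)c1` reaches only a limit of the assay there, > 100000 nM, which is also the limit noted as the limit of > 100000 nM in this assay, at which 1 of the 3 values shown sits. Compound 2 `Cc1cc(O)cc(-c2nn(CC#N)cc2-c2ccnc(-c3ccc(Oc4ccccc4)cc3)c2)c1` gives 35100 nM in this assay. Compound 3 `COc1cc(C)cc(-c2nn(CC#N)cc2-c2ccnc(-c3ccc(N(C)C)cc3)c2)c1` gives 3240 nM in this assay, the lower of the two real numbers, and its gap to compound 2 lies beyond the usual scatter.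

Compound 4 `Cc1cc(O)cc(-c2nn(CC#N)cc2-c2ccnc(-c3ccc(N(C)C)cc3)c2)c1` differs from compound 3 by hydrogen in place of methyl on an oxygen on an aromatic ring. Going by the values given here, no measured pair shows this change alone, since compound 2 carries the hydroxy but also another distal group. The step from compound 3 to compound 4 is expected to be modest, a 1.5-fold higher number from compound 3 to compound 4 (0.19 log units; within the scatter), toward a somewhat higher number. Compound 4 is therefore expected to give about 5000 nM in this assay, estimated between 1500 nM and 20000 nM.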

Compound 4, concentration lethal to 50% of the cells: 68100 nM
Beside the measured number, compound 4's estimate is 14-fold (1.13 log units) below it, outside the stated range (above it).
By their numbers in this assay, from the lowest: compound 3; then compounds 2 and 4 (each within the scatter of the next). At a limit, above all of these: compound 1.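

In this assay, going by these compounds alone, hydroxy in place of methoxy on the 3-methoxy-5-methylphenyl group gives a 21-fold higher number from compound 3 to compound 4 (1.32 log units; beyond the scatter) and shows that this oxygen substituent weighs heavily, which no earlier pair could show. With the hydroxy kept, dimethylamino in place of phenoxy gives a 1.9-fold higher number from compound 2 to compound 4 (0.29 log units; within the scatter) and so does not separate these two distal groups. Nothing shown here accounts for the size of the methoxy to hydroxy step.

Going by these compounds, whether that step holds with phenoxy or other distal groups remains open. So does what an ethoxy group or an amine at this oxygen-bearing position would give.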